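Swapping One Aromatic Ring Substituent in a Growth Inhibitor Series

The source may hold more compounds than are shown below. What is called first, only, known or untested is meant among the compounds shown, and "the series" means these compounds.

Of the compounds shown here, three built on one shared core have been tested in a functional assay on Jurkat cells (Homo sapiens) for inhibition, read by CCK-8 assay, with a stated time of 48 h; a higher number here means a weaker inhibitor of growth, a lower number a stronger inhibitor of growth. Compound 1 `Cc1ccccc1Nc1nc(NCc2ccccc2)ncc1Cl` carries a benzyl group on one of its nitrogens. For compound 1 this assay reports only a limit, > 100000 nM, rather than a number, as noted in the limit of > 100000 nM in this assay, at which 1 of the 3 values shown sits. Compound 2 `Cc1ccccc1Nc1nc(Nc2cc(Cl)ccn2)ncc1Cl` carries 4-chloropyridin-2-yl in place of that benzyl and gives 39600 nM, which is a step of an at least 2.5-fold lower number from compound 1 to compound 2 (0.40 log units; beyond the scatter). Compound 3 `Cc1ccccc1Nc1nc(Nc2ccc(N3CCN(C)CC3)cn2)ncc1Cl` gives 8080 nM in this assay, the lowest of the two numbers, with compound 2 as its nearest neighbour at a clearly higher number, beyond the usual scatter.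

Compound 4 `COc1cccc(Nc2nc(Nc3ccc(N4CCN(C)CC4)cn3)ncc2Cl)c1` has not yet been measured. It differs from compound 3 by 3-methoxyphenyl in place of 2-methylphenyl on a nitrogen on an aromatic ring. Among the compounds with values here, the only measured step, an at least 2.5-fold lower number from compound 1 to compound 2 (0.40 log units; beyond the scatter), alters the group on a different nitrogen, so no measured step bears on a change at this position, and nothing among the three compounds indicates which way the number should move. The expectation is therefore a step of a 1.0-fold lower number from compound 3 to compound 4 (0.00 log units; within the scatter), which is within the scatter. Compound 4 is thus expected to give about 8000 nM in this assay, estimated to lie between 2500 nM and 25000 nM.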

Compound 4, concentration for 50% growth inhibition: 15800 nM
The estimate for compound 4 lay 2.0-fold (0.30 log units) below the measured number; measured number inside the range.
By their numbers in this assay, from the lowest: compounds 3 and 4 (each within the scatter of the next); then compound 2. At a limit, above all of these: compound 1.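

In this assay, within the data shown here, putting 3-methoxyphenyl in place of 2-methylphenyl on this nitrogen gives a 2.0-fold higher number from compound 3 to compound 4 (0.29 log units; within the scatter) and so offers the first reading at this position, where the earlier step had changed only the group on the other nitrogen. Within the scatter, this exchange does not separate the two compounds, so this ring can carry a methoxy group in the 3 position instead of a methyl group in the 2 position with no clear difference in growth inhibition. The exchange alters both the substituent and its place on the ring, however, and the shown values give no explanation for the result and cannot assign any contribution to either alteration.

The compounds shown leave open how 3-methylphenyl or 2-methoxyphenyl would compare, which would be needed to tell the substituent from its place on the ring. They also leave open whether this ring can carry a very different group, such as an amine or a carboxylic acid, and whether any such group could bring a number clearly lower than those of compound 3 and compound 4.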